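This account rests on a few compounds, and the source may have more. Where it says the series, first, only, none or still open, it means among the compounds named here.

Compound 1 `COc1ccc2nc(C)cc(OCC(=O)Nc3cc(C)ccc3C)c2c1` and compound 2 `COc1ccc2nc(C)cc(OCC(=O)Nc3cc(OC)c(OC)c(OC)c3)c2c1` share one core and were both measured in a physicochemical assay for solubility, in phosphate buffer, measured as kinetic solubility, with a stated time of 1 h, at pH 7.4; on this read-out higher numbers stand for higher solubility and lower numbers for lower solubility. Compound 1 gives 45500 nM in this assay, and compound 2 gives 34000 nM; the two numbers lie within the scatter of one another, so neither compound stands apart from the other. Compound 3 `COc1ccc2nc(C)cc(OCC(=O)NC3CONC3=O)c2c1` has not yet been measured in this assay. It differs from compound 1 in a single place: a group of 6 heavy atoms (3 carbon, 1 nitrogen, 2 oxygen; one five-membered non-aromatic ring with 2 hetero atoms) in place of a group of 8 heavy atoms (8 carbon; one six-membered aromatic ring of carbon only), on an amide-type nitrogen. Going by the values given here, no step between two measured compounds is available to lean on, so the expectation rests only on this change, a group of 6 heavy atoms (3 carbon, 1 nitrogen, 2 oxygen; one five-membered non-aromatic ring with 2 hetero atoms) in place of a group of 8 heavy atoms (8 carbon; one six-membered aromatic ring of carbon only), on an amide-type nitrogen. A rise beyond the scatter is expected, roughly a 2.6-fold higher number from compound 1 to compound 3 (0.42 log units; beyond the scatter). Compound 3 is accordingly estimated at 120000 nM, with a range of 50000 nM to 300000 nM.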

Compound 3, solubility: >= 166000 nM
Compound 3: no number, only a limit; the forecaster's own chance of this, stated with the estimate: 20%; at least 1.3-fold (0.14 log units) between middle value and limit.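

In this assay, going by these compounds alone, the single change on the amide-type nitrogen, from 2,5-dimethylphenyl to the five-membered non-aromatic ring with 2 hetero atoms, gives an at least 3.6-fold higher number from compound 1 to compound 3 (0.56 log units; beyond the scatter). Within the data shown here, this is the only step read at this position, and it shows that the number here can move beyond the scatter, which compound 1 and compound 2 alone could not show, as no step joined them. For compound 3 the reading is a limit and not a number, so the step gives only a minimum size: the limit of >= 166000 nM in this assay, at which 1 of the 3 values shown sits.

The compounds shown leave open whether the step comes from losing 2,5-dimethylphenyl or from the ring that enters. They also leave open how a carboxylic acid, an amine or a simple open-chain amide on this nitrogen would compare with the ring in compound 3.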